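The source may report more compounds than this note shows. Statements on the series, on what has been measured and on what is new or still open speak of the compounds shown alone.

Among the measured compounds shown here, compound 1 `CCn1c(-c2ccccc2)nc2c(NC3CCCCC3)ncnc21` gives 707 nM in an assay on CHO cells for displacement of a labelled ligand from adenosine receptor A3 (Homo sapiens), read by scintillation counting, with a stated time of 3 h (on this read-out higher numbers stand for weaker inhibition and lower numbers for stronger inhibition), the lowest of the two numbers so far; compound 2 `CCn1c(-c2ccccc2)nc2c(NC3CCOC3)ncnc21`, the closest neighbour, gives 1660 nM, a step of a 2.3-fold higher number from compound 1 to compound 2 (0.37 log units; beyond the scatter) for oxolan-3-yl in place of cyclohexyl on a nitrogen on an aromatic ring. Compound 3 `CCCn1c(-c2ccccc2)nc2c(NC3CCCCC3)ncnc21` differs from compound 1 by methyl in place of hydrogen on a saturated chain carbon, two bonds along the chain from an aromatic nitrogen. No measured step touches the chain on the aromatic nitrogen, so nothing shown bears on this change. In this assay compound 3 is expected to stay within the scatter of compound 1, a step of about a 1.0-fold lower number from compound 1 to compound 3 (0.00 log units; within the scatter). The estimate for compound 3 is 700 nM, with a range from 250 nM to 2000 nM.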

Compound 3, inhibition constant: 2360 nM
Compound 3: middle estimate off by 3.4-fold (0.53 log units), on the low side; the measured number lies above the stated range.
By their numbers in this assay, from the lowest: compound 1; then compounds 2 and 3 (each within the scatter of the next).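

With one added methyl, the chain on the aromatic nitrogen proves to be a position that responds in this assay: ethyl to propyl gives a 3.3-fold higher number from compound 1 to compound 3 (0.52 log units; beyond the scatter). Until now, only the group on the other nitrogen had been varied. Nothing available explains this step.

From the compounds shown here alone, it remains open whether a methyl or a butyl chain on the aromatic nitrogen would continue this trend, and how a terminal hydroxyl on the propyl chain would read. Also open, going by these compounds, is whether the step would recur with oxolan-3-yl in place of cyclohexyl.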